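The source may hold more compounds than are shown below. What is called first, only, known or untested is meant among the compounds shown, and "the series" means these compounds.

Compound 1 `COc1cc(OC)cc(-c2cc3ccccc3c(-c3cccc(O)c3)n2)c1` and compound 2 `COc1cc(OC)cc(-c2cc3ccccc3c(-c3cccc(OC)c3)n2)c1` share one core and differ by a single change, (methyl in place of hydrogen on an oxygen on an aromatic ring). In an assay on isolated protein for inhibition of DNA topoisomerase 1 (Homo sapiens), with a stated time of 30 min, tested at 100 uM (a lower number here means a weaker effect, a higher number a stronger effect of the compound at the concentration tested), compound 1 gives 0%, and compound 2 gives 0%, so the step of no change at the digits printed from compound 1 to compound 2 (within the scatter). Compound 3 `COc1ccc(-c2cc3cc(C)ccc3c(-c3ccc(O)cc3)n2)cc1OC` is built on a different core; how the two cores differ is not broken down here. In this assay compound 3 gives 0.3%, a number that sits within the scatter of the other two. Compound 4 `COc1ccc(-c2nc(-c3ccc(OC)c(OC)c3)cc3cc(C)ccc23)cc1` is compound 3 with the same change applied, (methyl in place of hydrogen on an oxygen on an aromatic ring). Because the earlier step of no change at the digits printed from compound 1 to compound 2 (within the scatter) left the read-out unchanged, the step of a number 0.3 percentage points lower from compound 3 to compound 4 (within the scatter) is expected to be of the same kind and size. For compound 4 the estimated inhibition in this assay is 0%, likely between 0% and 6%.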

Compound 4, a percentage reported as inhibition, at one concentration (the size of the read-out at that concentration, not a potency): 2.3%
Estimate against measurement, compound 4: 2.3 percentage points below, and the stated range covers the measured number.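

Swapping hydrogen for methyl on an oxygen on an aromatic ring gives, in this assay, a number 2 percentage points higher from compound 3 to compound 4 (within the scatter). Set beside the earlier step, the change carries over from one core to the other with no difference that can be told apart: the same change on two cores in this assay, no change at the digits printed (within the scatter) from compound 1 to compound 2 and a number 2 percentage points higher (within the scatter) from compound 3 to compound 4, 2 percentage points apart, within the scatter of two such steps. Among the compounds shown here, all of these read-outs lie close to nothing at the single concentration tested, so this agreement shows only that the change stays within the scatter on weak compounds, and it cannot show how the change would behave on a core with clear inhibition.

Still open, going by these compounds, is whether a larger group on that oxygen, such as a longer chain or a chain ending in an amine, would give a clear read-out on either core.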